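Homologation of the nitrile arm in the oxime series

The source may hold more compounds than are shown below. What is called first, only, known or untested is meant among the compounds shown, and "the series" means these compounds.

Measured so far, each in a physicochemical assay for lipophilicity; a lower number here means a more polar compound, a higher number a more lipophilic compound:
compound 1 `COCCOCn1cc[n+](C)c1/C=N/O` gives -2.81
compound 2 `C[n+]1ccn(COCCC[Si](C)(C)C)c1/C=N/O` gives 0.43
compound 3 `C[n+]1ccn(CCC#N)c1/C=N/O` gives -3.3

Compound 3 stands lowest of the three numbers in this assay; its nearest neighbour is compound 1 a number 0.49 log units lower from compound 1 to compound 3 (beyond the scatter), and the furthest is compound 2 a number 3.24 log units higher from compound 1 to compound 2 (beyond the scatter).

Compound 4 `C[n+]1ccn(CCCC#N)c1/C=N/O`, not yet measured, differs from compound 3 by cyanomethyl in place of cyano on a saturated chain carbon, two bonds along the chain from an aromatic nitrogen. Among the compounds with values here, no measured step is a pure one-carbon homologation of this arm. The two that bear on it are the exchange of the arm itself, which was modest a number 0.49 log units lower from compound 1 to compound 3 (beyond the scatter), and the far larger swap of chain end a number 3.24 log units higher from compound 1 to compound 2 (beyond the scatter), in which a longer chain went with a much higher number. A single added chain carbon is expected to move the number up by a small amount, in this assay close to the edge of the scatter.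

Compound 4 is therefore estimated at -2.9, with a range from -3.4 to -2.4, which means an expected step of a number 0.40 log units higher from compound 3 to compound 4 (beyond the scatter).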

Compound 4, distribution coefficient: < -3
Compound 4 was reported as a limit; the forecaster's own chance of this, stated with the estimate: 5%; middle value at least 0.10 log units from the limit.
By their numbers in this assay, from the lowest: compound 3; then compound 1; then compound 2.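

In this assay compound 4 is reported only as a limit, < -3. The step for cyanomethyl in place of cyano, the one-carbon extension of the nitrile arm from compound 3, cannot be read, because the value for compound 4 is not a number: the limit of < -3 in this assay, at which 1 of the 4 values shown sits. With 2-cyanoethyl in place of 2-methoxyethoxy, the reading is a number at least 0.19 log units lower from compound 1 to compound 4 (that floor lies within the scatter), so the extended nitrile arm shows nothing like the rise of a number 3.24 log units higher from compound 1 to compound 2 (beyond the scatter).

As far as these compounds go, the size and even the direction of the effect of one added chain carbon on this arm remain open. A longer chain ending in a nitrile, or a carboxylic acid or an amine in place of the nitrile, would need a number above the limit of the assay to give a readable step at this position.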